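The compounds below may be only part of what the source reports. "The series", "measured", "known", "first", "only" and "open" are said of these compounds alone.

For the measured compounds named here, only two compounds have numbers so far. In a functional assay on the whole organism (strain Kunming) with Mus musculus as the target, with a stated time of 0.5 h (a lower number here means that less compound is needed, a higher number that more compound is needed for the effect), compound 1 (`COc1ccccc1/C=C/C(=O)OC/C=C/c1cc(OC)c(OC)cc1OC`) gives 240 mg/kg and compound 2 (`COc1cc(OC)c(OC)cc1/C=C/COC(=O)/C=C/c1cc(OC)c(OC)c(OC)c1OC`) gives 155 mg/kg. Going by the values given here, these two values lie within the scatter of each other, so compound 1 stands level with the only other measured compound and neither can be ranked. The two also differ in more than one place, so no single structural change can be read from them.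

Compound 3 (`COc1cc(OC)c(OC)cc1/C=C/COC(=O)/C=C/c1ccccc1C(F)(F)F`) keeps the core of compound 1 and changes one group: trifluoromethyl in place of methoxy on an aromatic carbon. Trifluoromethyl takes the place of methoxy on an aromatic carbon, ortho to a large group. Among the compounds with values here, no measured pair shows this exchange in this assay, so the data offer no direct guide to its size or direction. Within the data shown here, the only guide is the narrow spread between compound 1 at 240 mg/kg and compound 2 at 155 mg/kg, and on that basis no change beyond the scatter is expected. The expected step is a 1.3-fold lower number from compound 1 to compound 3 (0.10 log units; within the scatter), which is a modest estimate with no firm direction. For compound 3 the estimated value is 190 mg/kg, with an expected range from 90 mg/kg to 400 mg/kg.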

Compound 3, dose for half-maximal effect: > 200 mg/kg
Compound 3: no number, only a limit (the forecaster's own chance of this, stated with the estimate: 15%); at least 1.0-fold (0.02 log units) between middle value and limit.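

In this assay compound 3 gives > 200 mg/kg as a limit and not a number. For the compounds shown here, no step from compound 1 to compound 3 can therefore be read: the limit of > 200 mg/kg in this assay, at which 1 of the 3 values shown sits. The compounds shown leave open what trifluoromethyl in place of methoxy on an aromatic carbon does to the number in this assay.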